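The source may report more compounds than this note shows. Statements on the series, on what has been measured and on what is new or still open speak of the compounds shown alone.

Measured compounds:
Compound 1 `Oc1ccc(-c2cc(-c3cccs3)cc(-c3cccc(O)c3)n2)cc1` gives 85.7%.
Compound 2 `Oc1ccc(-c2cc(-c3cccs3)cc(-c3ccc(O)cc3)n2)cc1` gives 86.3%.
Compound 3 `Oc1cccc(-c2cc(-c3ccco3)cc(-c3ccccc3O)n2)c1` gives 90.1%.

All three compounds were examined in an assay on isolated protein for inhibition of DNA topoisomerase 1 (Homo sapiens), with a stated time of 30 min, tested at 100 uM; a lower number here means a weaker effect, a higher number a stronger effect of the compound at the concentration tested. Compound 1 and compound 2 share one core and differ in a single place: 4-hydroxyphenyl in place of 3-hydroxyphenyl on an aromatic carbon. This change moved the inhibition by a number 0.6 percentage points higher from compound 1 to compound 2 (within the scatter), so the two numbers cannot be told apart. Compound 3 carries a different core; the difference between the core of compound 3 and the core of compound 1 is not broken down here. The values of compound 3, compound 2 and compound 1 all lie within the usual scatter of one another, so no order among them can be read from these data.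

Compound 4 `Oc1ccc(-c2cc(-c3ccco3)cc(-c3ccccc3O)n2)cc1` has not yet been measured in this assay. It is related to compound 3 by 4-hydroxyphenyl in place of 3-hydroxyphenyl on an aromatic carbon. Among the measured compounds shown here, this is the same kind of change as the one from compound 1 to compound 2, but the surroundings are not the same: in compound 3 the place is meta to a 2-hydroxyphenyl group and meta to a furan-2-yl group, whereas in compound 1 it is meta to a 4-hydroxyphenyl group and meta to a thiophen-2-yl group. For the measured compounds named here, the step from compound 3 to compound 4 is expected to be a number 1.1 percentage points lower from compound 3 to compound 4 (within the scatter), because the only measured example of this kind of change gave a number 0.6 percentage points higher from compound 1 to compound 2 (within the scatter) from compound 1 to compound 2. Compound 4 is therefore estimated at 89%, with an expected range from 80% to 96%.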

Compound 4, a percentage reported as inhibition, at one concentration (the size of the read-out at that concentration, not a potency): 83%
Compound 4: the middle estimate sits 6 percentage points above what was measured; low and high end bracket the measured number.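

In this assay, exchanging 3-hydroxyphenyl for 4-hydroxyphenyl on the core of compound 3 gave a number 7.1 percentage points lower from compound 3 to compound 4 (within the scatter), so the two numbers cannot be told apart. Set beside the earlier step on the core of compound 1, this step does not differ from it: the same change on two cores in this assay, a number 0.6 percentage points higher (within the scatter) from compound 1 to compound 2 and a number 7.1 percentage points lower (within the scatter) from compound 3 to compound 4, 7.7 percentage points apart, within the scatter of two such steps On these two cores, then, the change leaves the inhibition within the usual scatter and the data give no sign that the core alters its outcome, but two pairs read at a single concentration do not show that the change is without effect on potency, nor that it would behave the same way on any further core.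

The compounds shown leave open whether these close readings would separate at lower concentrations, where a full concentration series could reveal differences that a single high concentration does not. They also leave open how the inhibition would respond if an amine or a carboxylic acid stood in place of the hydroxyl on these phenyl rings, or if a group other than furan-2-yl or thiophen-2-yl occupied that place on the core.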